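Swapping an Aromatic Group for Ethyl on a Sulfur Chain

The source may report more compounds than this note shows. Statements on the series, on what has been measured and on what is new or still open speak of the compounds shown alone.

In a functional assay on MGC-803 cells (Homo sapiens) for inhibition, read by MTT assay, with a stated time of 72 h (a lower number here means a stronger inhibitor, a higher number a weaker inhibitor), compound 1 (`Cc1cc(N2CC[C@@H](C)[C@@H](N(C)c3ncnc4[nH]ccc34)C2)n2nc(SCc3csc4ccc(Cl)cc34)nc2n1`) gives > 100000 nM as a limit of the assay, not a number. Compound 2 (`Cc1cc(N2CC[C@@H](C)[C@@H](N(C)c3ncnc4[nH]ccc34)C2)n2nc(SCC3CCCCC3)nc2n1`) gives 9170 nM and compound 3 (`COc1ccc(CSc2nc3nc(C)cc(N4CC[C@@H](C)[C@@H](N(C)c5ncnc6[nH]ccc56)C4)n3n2)cc1`) gives 15200 nM here, two values within the scatter of each other. Compound 4 (`CCCSc1nc2nc(C)cc(N3CC[C@@H](C)[C@@H](N(C)c4ncnc5[nH]ccc45)C3)n2n1`) has ethyl in place of 4-methoxyphenyl on a saturated chain carbon bound to a sulfur. The steps of an at least 10-fold lower number from compound 1 to compound 2 (1.03 log units; beyond the scatter) and an at least 6.5-fold lower number from compound 1 to compound 3 (0.81 log units; beyond the scatter) are sizeable, but they start from a limit and remove 5-chloro-1-benzothiophen-3-yl, a group absent from compound 3 and compound 4. The step of a 1.7-fold higher number from compound 2 to compound 3 (0.22 log units; within the scatter) bears more directly: it changes the group at that same place and stays within the scatter. No step beyond the scatter is therefore expected, and the estimated change is a 1.2-fold lower number from compound 3 to compound 4 (0.07 log units; within the scatter) in this assay. For compound 4 the estimate is 13000 nM with an expected range from 5000 nM to 35000 nM in this measurement.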

Compound 4, half-maximal inhibitory concentration: 15500 nM
Compound 4: the middle estimate sits 1.2-fold (0.08 log units) below what was measured, within the range that was stated.
By their numbers in this assay, from the lowest: compounds 2, 3 and 4 (each within the scatter of the next). At a limit, above all of these: compound 1.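

In this assay, the 4-methoxyphenyl group, with its aromatic ring and oxygen, can give way to the much smaller ethyl without a change that can be told from the scatter: a 1.0-fold higher number from compound 3 to compound 4 (0.01 log units; within the scatter). Ethyl in place of cyclohexyl gives the same picture, a 1.7-fold higher number from compound 2 to compound 4 (0.23 log units; within the scatter), so a ring on this chain carbon is not needed to keep these values. Only compound 1 stands apart, an at least 6.4-fold lower number from compound 1 to compound 4 (0.80 log units; beyond the scatter), and that step is a bound, not a measured size: the limit of > 100000 nM in this assay, at which 1 of the 4 values shown sits.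

Still open, going by these compounds, is whether an amine, a carboxylic acid or a chain longer than propyl at this place would give a lower number, beyond the scatter.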